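This account rests on a few compounds, and the source may have more. Where it says the series, first, only, none or still open, it means among the compounds named here.

Compound 1 `N#CC1CN1C(=O)Nc1ccc(S(N)(=O)=O)cc1` gives in a functional assay on WiDr cells (Homo sapiens) for inhibition (on this read-out lower numbers stand for stronger inhibition and higher numbers for weaker inhibition), only a limit, > 38000 nM.
Compound 2 `CCCCNC(=O)N1CC1C#N` gives 14000 nM in this assay.
Compound 3 `CNC(=O)N1CC1C#N` gives 21000 nM in this assay.

Going by the values given here, only two numbers are available, and compound 3 sits beside compound 2: the step of a 1.5-fold higher number from compound 2 to compound 3 (0.18 log units; within the scatter) lies within the scatter, so the two cannot be told apart. For compound 1 the assay reports a limit rather than a number, as stated in the limit of > 38000 nM in this assay, at which 1 of the 3 values shown sits.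

Compound 4 `CC(C)(C)NC(=O)N1CC1C#N` is not yet measured. It differs from compound 3 in one place: tert-butyl in place of methyl on an amide-type nitrogen. The larger group enters on the amide-type nitrogen whose other neighbour is the carbonyl carbon.

Among the compounds with values here, the only measured step that bears on this change is a 1.5-fold higher number from compound 2 to compound 3 (0.18 log units; within the scatter), where a chain on that part of the molecule was shortened to hydrogen without a shift beyond the scatter. That step offers no sign that the size of the group on this nitrogen moves the number in this assay. Going the other way, to a bulkier tert-butyl, is therefore expected to give no step beyond the scatter.

Compound 4 is expected to give 18000 nM in this assay, with a range from 7000 nM to 45000 nM. The expected step is a 1.2-fold lower number from compound 3 to compound 4 (0.07 log units; within the scatter), within the scatter.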

Compound 4, half-maximal inhibitory concentration: 180000 nM
For compound 4 the middle estimate is 10-fold (1.00 log units) below the measured one, outside the stated range (above it).
By their numbers in this assay, from the lowest: compounds 2 and 3 (each within the scatter of the next); then compound 4.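

Putting tert-butyl in place of methyl on the amide-type nitrogen gives an 8.6-fold higher number from compound 3 to compound 4 (0.93 log units; beyond the scatter) in this assay, and putting it in place of butyl gives a 13-fold higher number from compound 2 to compound 4 (1.11 log units; beyond the scatter) on the same read-out, so what sits on this nitrogen does affect the number. Methyl and butyl could not be told apart, which means that a longer chain alone does not account for the weaker inhibition of compound 4, and the branched tert-butyl is the group that stands apart among the three. Nothing measured here gives a reason for this difference.

From the compounds shown here alone, whether the weaker inhibition already appears with a smaller branched group such as isopropyl, or also with a ring such as cyclohexyl, remains open. The compounds shown also leave open how a chain ending in an amine or a carboxylic acid would behave on this nitrogen, and whether any group there could bring the number clearly below those of compound 2 and compound 3.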